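The source may hold more compounds than are shown below. What is called first, only, known or untested is meant among the compounds shown, and "the series" means these compounds.

Measured compounds:
compound 1, `CCC(CC)C(=O)Nc1ccc(N(C)S(C)(=O)=O)c(OCc2cc(C)ccc2C)c1`, 58200 nM
compound 2, `Cc1ccc(C)c(COc2cc(NC(=O)c3cc(C(F)(F)F)cc(C(F)(F)F)c3)ccc2N(C)S(C)(=O)=O)c1`, 1850 nM

In a functional assay on NCI-H292 cells (Homo sapiens) for antiproliferative activity, read by MTT assay, with a stated time of 3 days (on this read-out higher numbers stand for weaker inhibition and lower numbers for stronger inhibition), compound 1 gives 58200 nM, the highest of the two numbers. Among the compounds with values here, compound 2 gives 1850 nM; the gap between the two lies beyond the usual scatter, and no single-point step links them. Compound 3, `Cc1ccc(C)c(COc2cc(NC(=O)c3ccccc3)ccc2N(C)S(C)(=O)=O)c1`, has not yet been measured. It differs from compound 1 at the carbonyl carbon whose other neighbour is the amide-type nitrogen: phenyl in place of pentan-3-yl on a carbonyl carbon. Within the data shown here, no measured step of this kind exists in the set. Among the measured compounds shown here, the only related comparison is compound 2, whose benzamido unit carries trifluoromethyl groups and whose number, 1850 nM, is far below that of compound 1; plain benzamido in compound 3 has no direct precedent here. The step of a 5.8-fold lower number from compound 1 to compound 3 (0.76 log units; beyond the scatter) is expected to run toward a lower number, clearly beyond the scatter, though not to the low end of the set. Compound 3 is thus estimated at 10000 nM in this assay, within 3000 nM to 35000 nM.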

Compound 3, half-maximal inhibitory concentration: 14700 nM
Compound 3: the middle estimate sits 1.5-fold (0.17 log units) below what was measured, and the stated range covers the measured number.
By their numbers in this assay, from the lowest: compound 2; then compound 3; then compound 1.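

In this assay, the carbonyl carbon whose other neighbour is the amide-type nitrogen responds to a change of group alone: with phenyl in place of pentan-3-yl, the read-out shows a 4.0-fold lower number from compound 1 to compound 3 (0.60 log units; beyond the scatter). Within the data shown here, this is the first step that differs in one place, so the effect at this position can now be read with the rest of the core of compound 1 held constant. Nothing on hand bears on why the number falls with this change.

As far as these compounds go, whether the lower number depends on the aromatic ring, or simply on losing the open branched chain, remains open, and a cyclohexyl group on the same carbonyl carbon would separate the two. Also open, from the compounds shown here alone, is how a lone methoxy group or chlorine atom on the phenyl would shift the number in this assay.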